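The compounds below may be only part of what the source reports. "The series", "measured", "known", "first", "only" and "open" are said of these compounds alone.

Notes on the series, with values from a physicochemical assay for solubility, at pH 6.8 (a lower number here means a less soluble compound, a higher number a more soluble compound), as measured so far

- compound 1 `CN1CCc2nc(C(=O)NC3CN(S(C)(=O)=O)CCC3NC(=O)c3cc4cc(Cl)ccc4[nH]3)sc2C1` at 103 ug/mL
- compound 2 `COC(=O)CN1CC[C@H](NC(=O)c2cc3cc(Cl)ccc3[nH]2)[C@H](NC(=O)c2nc3c(s2)CN(C)CC3)C1` at 28 ug/mL
- compound 3 `CC(=O)N1CCC(NC(=O)c2nc3c(s2)CN(C)CC3)C(NC(=O)c2cc3cc(Cl)ccc3[nH]2)C1` at 290 ug/mL

Compound 3 is the highest of the three, and the gaps down to compound 1 and to compound 2 both lie beyond the scatter. Compound 4 `CCOC(=O)N1CCC(NC(=O)c2nc3c(s2)CN(C)CC3)C(NC(=O)c2cc3cc(Cl)ccc3[nH]2)C1` carries ethoxy in place of methyl on a carbonyl carbon of compound 3, which reads as acetyl to ethoxycarbonyl (ethoxy in place of methyl on a carbonyl carbon). Within the data shown here, no two measured compounds differ in one place, so this change has no direct precedent here and the expected step rests only on the spread of the three values. Compound 3 at 290 ug/mL marks the top of that spread and compound 2 at 28 ug/mL marks the bottom, so a fall is expected rather than a rise. The expected change in this assay is a 3.2-fold lower number from compound 3 to compound 4 (0.51 log units; beyond the scatter) and is estimated to lie beyond the scatter, with low confidence. For compound 4 the estimated value is 90 ug/mL within an expected range of 30 ug/mL to 260 ug/mL on these thin data.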

Compound 4, solubility: 37 ug/mL
Compound 4: the middle estimate sits 2.4-fold (0.39 log units) above what was measured; low and high end bracket the measured number.
By their numbers in this assay, from the lowest: compounds 2 and 4 (each within the scatter of the next); then compound 1; then compound 3.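

Acetyl to ethoxycarbonyl is the first change in the series that can be read in one place: in this assay it gives a 7.8-fold lower number from compound 3 to compound 4 (0.89 log units; beyond the scatter) and so lies beyond the scatter. This shows that the group on this carbonyl carbon, whose other neighbour is the amide-type nitrogen in a ring, is not a silent position for this read-out, at least when methyl gives way to ethoxy. No measurement at hand accounts for the size of this step.

From the compounds shown here alone, a single step cannot separate the entering oxygen from the longer chain, so it remains open which of the two goes with the drop. Methoxy, ethyl or a dimethylamino group on the same carbonyl carbon would each bear on that question, and the direction of the step is known for ethoxy alone.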